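Second fluoro on the naphthyl ring of a hydroxamate

This account rests on a few compounds, and the source may have more. Where it says the series, first, only, none or still open, it means among the compounds named here.

Compound 1: `CC(C)(C)[C@H](NC(=O)[C@H](Cc1ccc2ccccc2c1)[C@H](O)C(=O)NO)C(N)=O`, 20 nM
Compound 2: `CC(C)(C)[C@H](NC(=O)[C@H](Cc1ccc2ccc(F)cc2c1)[C@H](O)C(=O)NO)C(N)=O`, 80 nM

In an assay on isolated protein for inhibition of low affinity immunoglobulin epsilon Fc receptor (Homo sapiens) (a higher number here means a weaker inhibitor, a lower number a stronger inhibitor), compound 1 gives 20 nM and compound 2 gives 80 nM. Among the compounds with values here, of the two numbers measured so far, compound 2 holds the higher one; its nearest neighbour is compound 1, and the step of a 4.0-fold higher number from compound 1 to compound 2 (0.60 log units; beyond the scatter) lies beyond the scatter. That step is the only one measured here, and it shows that a fluoro in place of hydrogen on an aromatic carbon of the shared core weakened the inhibitor.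

Compound 3, `CC(C)(C)[C@H](NC(=O)[C@H](Cc1ccc2cc(F)c(F)cc2c1)[C@H](O)C(=O)NO)C(N)=O`, carries one further change of the same kind: fluoro in place of hydrogen on an aromatic carbon. Within the data shown here, the single step on record for this sort of change, a 4.0-fold higher number from compound 1 to compound 2 (0.60 log units; beyond the scatter), is the only guide, and a second fluoro need not behave exactly like the first. The account therefore expects the number for compound 3 in this assay to move in the same direction as before, though by a smaller amount, and the expected step of a 2.0-fold higher number from compound 2 to compound 3 (0.30 log units; within the scatter) is a modest one. For compound 3 the estimate in this assay is 160 nM, with a range from 60 nM to 500 nM.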

Compound 3, half-maximal inhibitory concentration: > 1000 nM
Compound 3 ended at the assay's limit; the forecaster's own chance of this, stated with the estimate: 3%; middle value at least 6.2-fold (0.79 log units) away from the limit.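

Replacing hydrogen with fluoro on an aromatic carbon of the shared core gave a modest loss the first time, a 4.0-fold higher number from compound 1 to compound 2 (0.60 log units; beyond the scatter), and a large one the second time, an at least 12-fold higher number from compound 2 to compound 3 (1.09 log units; beyond the scatter). The reading for compound 3 is a limit of this assay and not a number, so the second step gives only a minimum size: the limit of > 1000 nM in this assay, at which 1 of the 3 values shown sits. Across these three compounds, the effect of a fluoro is therefore not a fixed increment, since the new fluoro, ortho to a fluoro group, meta to a fused ring and para to a fused ring, is followed by a much larger weakening than the first one was, even though the group exchanged is the same.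

What the compounds shown leave open is whether a single fluoro at this position, with no other fluoro on the ring, would weaken the inhibitor as much, or whether the large step belongs to the two fluoro groups together. They also leave open how a chlorine, a methyl or a methoxy group would fare at this position, and how far compound 3 lies past its limit.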